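Adding a second chloro to a pyrazoline series

The source may hold more compounds than are shown below. What is called first, only, known or untested is meant among the compounds shown, and "the series" means these compounds.

Measured so far, in a functional assay on MCF7 cells (Homo sapiens) for antiproliferative activity, read by MTT assay, with a stated time of 24 h; a lower number here means a stronger inhibitor, a higher number a weaker inhibitor:
compound 1 `Clc1ccc(C2CC(c3ccccc3)=NN2c2ccc(-c3ccccc3)nn2)cc1` gives 100000 nM
compound 2 `Fc1ccc(C2CC(c3ccccc3)=NN2c2ccc(-c3ccccc3)nn2)cc1` gives 100000 nM
compound 3 `FC(F)(F)c1ccc(C2CC(c3ccccc3)=NN2c2ccc(-c3ccccc3)nn2)cc1` gives 100000 nM

Compound 1 stands level with compounds 2 and 3 at the digits shown. The three differ only in the group on one aromatic ring, and swapping that group left the read-out unchanged within the scatter: no change at the digits printed from compound 1 to compound 2 (within the scatter), no change at the digits printed from compound 1 to compound 3 (within the scatter) and no change at the digits printed from compound 2 to compound 3 (within the scatter) are all flat steps.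

Compound 4 `Clc1ccc(C2=NN(c3ccc(-c4ccccc4)nn3)C(c3ccc(Cl)cc3)C2)cc1` has not yet been measured. It differs from compound 1 by chloro in place of hydrogen on an aromatic carbon, so the second phenyl of the shared core now also carries a chloro.

For the measured compounds named here, no measured step adds a group to that second ring, so none bears directly on this change. What the data show is that three variations on the other ring produced no movement at all in this assay, and every compound sits at the same level. On that basis, the step from compound 1 to compound 4 is expected to be no change beyond the scatter, no change at the digits printed from compound 1 to compound 4 (within the scatter). Compound 4 is therefore estimated at 100000 nM, with a range from 40000 nM to 100000 nM.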

Compound 4, half-maximal inhibitory concentration: 8800 nM
The estimate for compound 4 lay 11-fold (1.06 log units) above the measured number; the measured number lies below the stated range.
By their numbers in this assay, from the lowest: compound 4; then compounds 1, 2 and 3 (each within the scatter of the next).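

In this assay, turning the phenyl of the shared core into a 4-chlorophenyl gives an 11-fold lower number from compound 1 to compound 4 (1.06 log units; beyond the scatter), so one added chloro, para to a large group, is enough to move a read-out that had stayed flat. Changes on the other ring had shown no such movement, as in no change at the digits printed from compound 1 to compound 2 (within the scatter) and no change at the digits printed from compound 1 to compound 3 (within the scatter), so this second ring is the first place in the series where a change registers, and the flat steps on the other ring turn out to say nothing about it. Nothing available here explains why this chloro has such an effect.

On these data alone, this rests on a single step, so it remains open whether the gain belongs to chloro itself or whether another group at this position, such as a methoxy, an amine or a carboxylic acid, would move the number as far, or in the opposite direction. As far as these compounds go, it is also open whether the same addition would work with the fluoro of compound 2 or the trifluoromethyl of compound 3 on the other ring, or whether it needs the chloro that compound 1 carries there.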